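Cytotoxicity of a Pyridyl-Triazole Series in Fibroblasts

This account rests on a few compounds, and the source may have more. Where it says the series, first, only, none or still open, it means among the compounds named here.

Compound 1 `Nc1cc2c(-n3nc(-c4ccccn4)nc3N)ncnc2cc1Cl`: 27000 nM
Compound 2 `COc1cc2ncnc(-n3nc(-c4ccccn4)nc3N)c2cc1N`: "not determined" (no result reported)

In an ADME assay on BJ cells (Homo sapiens) for cytotoxicity, with a stated time of 72 h (on this read-out higher numbers stand for an effect only at larger amounts of compound and lower numbers for an effect already at smaller amounts), compound 1 gives 27000 nM. As far as these compounds go, compound 2 was carried through the same test, yet its entry reads "not determined" (no result reported), so its standing on this read-out is unknown; only compound 1 anchors the series. Compound 3 `COc1cc2ncnc(-n3nc(-c4ccccn4)nc3N)c2cc1OCCCNC(=O)OC(C)C` is the compound still to be measured. It differs from compound 2 in one place: 3-((isopropoxycarbonyl)amino)propoxy in place of amino on an aromatic carbon. The chain enters on an aromatic carbon of a six-membered aromatic ring of carbon only, part of a fused or bridged system of two rings, ortho to a methoxy group. Among the measured compounds shown here, with no pair of measured compounds to compare, the size of the step from compound 2 to compound 3 in this assay cannot be read from the data; a shift within the scatter, in either direction, is the most that can be expected. Compound 3 is expected to give about 20000 nM, within 5000 nM to 60000 nM.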

Compound 3, half-maximal effective concentration: > 13000 nM
Compound 3 gave a limit, no number; the forecaster's own chance of this, stated with the estimate: 30%; the middle value is on the limit's open side.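

No step can be read between compound 2 and compound 3: compound 2 has no number, and the entry for compound 3, > 13000 nM, is a limit. The compounds shown leave open whether 3-((isopropoxycarbonyl)amino)propoxy in place of amino changes the result at all in this assay.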